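Trifluoromethoxy for fluoro on an aromatic carbon

The source may hold more compounds than are shown below. What is called first, only, known or untested is meant among the compounds shown, and "the series" means these compounds.

Measured in a functional assay on LNCaP cells (Homo sapiens) for antiproliferative activity, read by propidium iodide staining, with a stated time of 96 h; on this read-out lower numbers stand for stronger inhibition and higher numbers for weaker inhibition:
compound 1 `CC(O)(CSc1ccc(F)cc1)C(=O)Nc1ccc(S(F)(F)(F)(F)F)cc1` gives 12500 nM
compound 2 `CC(O)(CSc1cccc(C(F)(F)F)c1)C(=O)Nc1ccc(S(F)(F)(F)(F)F)cc1` gives 18300 nM
compound 3 `CC(O)(CSc1ccccc1C(F)(F)F)C(=O)Nc1ccc(S(F)(F)(F)(F)F)cc1` gives 12300 nM

All three numbers lie within the scatter of one another, so compound 1 stands level with the other two. Compound 4 `CC(O)(CSc1ccc(OC(F)(F)F)cc1)C(=O)Nc1ccc(S(F)(F)(F)(F)F)cc1` keeps the core of compound 1 and changes one group: trifluoromethoxy in place of fluoro on an aromatic carbon. This places trifluoromethoxy in place of fluoro on an aromatic carbon, para to a large group. The nearest evidence comes from other changes to the group on the sulfur: a 1.5-fold higher number from compound 1 to compound 2 (0.17 log units; within the scatter), a 1.0-fold lower number from compound 1 to compound 3 (0.01 log units; within the scatter) and a 1.5-fold lower number from compound 2 to compound 3 (0.17 log units; within the scatter). Each stays within the scatter, but none of these compounds carries trifluoromethoxy, so the evidence is indirect. No step beyond the scatter is therefore expected in this assay. The expected step is a 1.0-fold higher number from compound 1 to compound 4 (0.02 log units; within the scatter). For compound 4 the estimated value is 13000 nM, with an expected range from 7000 nM to 25000 nM.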

Compound 4, half-maximal inhibitory concentration: 16100 nM
Compound 4: middle estimate off by 1.2-fold (0.09 log units), on the low side, within the range that was stated.
By their numbers in this assay, from the lowest: compounds 3, 1, 4 and 2 (each within the scatter of the next).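

In this assay, the first change made directly at this place, para to a large group, gives a 1.3-fold higher number from compound 1 to compound 4 (0.11 log units; within the scatter). Trifluoromethoxy brings more heavy atoms and a hydrogen-bond acceptor to the aromatic carbon that held fluoro, yet the number stays within the scatter. No measurement shown here bears on why the read-out stays level. On these data alone, whether an amine or a carboxylic acid at this place would give a step beyond the scatter remains open. All four compounds stand level, so no change on the group on the sulfur has yet been seen to move the number.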